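A few compounds are considered here, and "the series" means these few. Any claim that something is new, unique, unknown or untested is made for them only; others in the source may bear on it.

Within the data shown here, in an ADME assay on MT4 cells (Homo sapiens) for cytotoxicity, read by MTT assay, with a stated time of 96 h (a higher number here means that more compound is tolerated, a lower number that less compound is tolerated), compound 3 `C/C(=N\NC(N)=S)c1ccc2[nH]c(-c3ccc(Cl)cc3)nc2c1` gives 2000 nM, the lowest actual number so far. Compound 1 `C/C(=N\O)c1ccc2[nH]c(-c3ccc(Cl)cc3)nc2c1`, which also carries the 4-chlorophenyl group, gives 20000 nM. Compound 2 `C/C(=N\NC(N)=S)c1ccc2[nH]c(-c3ccccc3)nc2c1`, which has no chloro, gives >= 100000 nM, and this is a limit of the assay and not a number.

The next compound, compound 4 `COc1ccc(-c2nc3cc(/C(C)=N/NC(N)=S)ccc3[nH]2)cc1`, differs from compound 3 in one group: methoxy in place of chloro on an aromatic carbon. In words, this is methoxy in place of chloro on an aromatic carbon. The most relevant measured change is at the same place, chloro in place of hydrogen, and it gave a large step, an at least 50-fold lower number from compound 2 to compound 3 (1.69 log units; beyond the scatter). The change elsewhere in the molecule gave a modest one, a 10-fold lower number from compound 1 to compound 3 (1.00 log units; beyond the scatter), and says less about this swap.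

Among the measured compounds shown here, no methoxy compound has been measured, so the effect of this group in this assay remains open. Since compound 4 gives up the chloro that marks the large step of an at least 50-fold lower number from compound 2 to compound 3 (1.69 log units; beyond the scatter), a partial return towards compound 2 seems likely, meaning a higher number by a modest amount. The expected change is a 5.0-fold higher number from compound 3 to compound 4 (0.70 log units; beyond the scatter). For compound 4, the estimated value is 10000 nM, with an expected range from 2500 nM to 50000 nM.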

Compound 4, half-maximal cytotoxic concentration: 5000 nM
Estimate against measurement, compound 4: 2.0-fold (0.30 log units) above; low and high end bracket the measured number.
By their numbers in this assay, from the lowest: compound 3; then compound 4; then compound 1. At a limit, above all of these: compound 2.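

The earlier compounds shown here showed only that chloro at this place goes with a lower number, and the swap from 4-chlorophenyl to 4-methoxyphenyl now shows in this assay that this is not a matter of chloro alone: methoxy stays fairly close to chloro, with a 2.5-fold higher number from compound 3 to compound 4 (0.40 log units; beyond the scatter), a modest step, though one beyond the scatter. Methoxy in place of hydrogen gives a far larger step, an at least 20-fold lower number from compound 2 to compound 4 (1.30 log units; beyond the scatter), so both groups at this place lower the number by much more than they differ from each other. Compound 2 stands at a limit and not at a number, so every step from it has only one firm end: the limit of >= 100000 nM in this assay, at which 1 of the 4 values shown sits.

The compounds shown leave open whether any group at this place would lower the number or only these two, and an amine, a carboxylic acid or a longer chain such as ethoxy would test that. Also open, as far as these compounds go, is whether methoxy would give a step of similar size on compound 1, which carries a different group on the double-bonded nitrogen.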